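Aryl ring substitution and cytotoxicity limits in one series

A few compounds are considered here, and "the series" means these few. Any claim that something is new, unique, unknown or untested is made for them only; others in the source may bear on it.

Measured compounds:
Compound 1, `CCOC(=O)C1=C(C)N(c2ccccc2)C(C)=C(C(=O)OCC)C1c1cn(-c2ccccc2)nc1-c1ccccc1`: > 10 ug/mL
Compound 2, `CCOC(=O)C1=C(C)N(c2ccccc2C)C(C)=C(C(=O)OCC)C1c1cn(-c2ccccc2)nc1-c1ccccc1`: > 10 ug/mL
Compound 3, `CCOC(=O)C1=C(C)N(c2ccccc2Cl)C(C)=C(C(=O)OCC)C1c1cn(-c2ccccc2)nc1-c1ccccc1`: > 10 ug/mL

In an ADME assay on Vero cells (Chlorocebus sabaeus) for cytotoxicity (on this read-out lower numbers stand for stronger inhibition and higher numbers for weaker inhibition), compound 1 gives > 10 ug/mL, which is a limit of the assay and not a number. Compound 2 gives a limit as well, > 10 ug/mL. Compound 3 also stands at a limit, > 10 ug/mL. The steps a step that the two limits leave unreadable from compound 1 to compound 2 and a step that the two limits leave unreadable from compound 1 to compound 3 are unreadable due to the limit of > 10 ug/mL in this assay, at which 3 of the 3 values shown sit, and the same holds for a step that the two limits leave unreadable from compound 2 to compound 3 due to the limit of > 10 ug/mL in this assay, at which 3 of the 3 values shown sit.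

Compound 4, `CCOC(=O)C1=C(C)N(c2cccc(Cl)c2)C(C)=C(C(=O)OCC)C1c1cn(-c2ccccc2)nc1-c1ccccc1`, differs from compound 1 by chloro in place of hydrogen on an aromatic carbon. The nearest measured comparison is the step from compound 1 to compound 3, the same change at a different place, which is unreadable in size. Among the compounds with values here, no measured step gives a readable size, so nothing indicates a move away from the limit for compound 4 in this assay. Compound 4 is expected to give 25 ug/mL, with a range of 10 ug/mL to 100 ug/mL, most probably again as a limit. The expected step is therefore a step that the limit leaves unreadable from compound 1 to compound 4, not readable against the limit.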

Compound 4, half-maximal inhibitory concentration: 7.08 ug/mL
Compound 4: the middle estimate sits 3.5-fold (0.55 log units) above what was measured; measured number below the stated range.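

In this assay, within the data shown here, 3-chlorophenyl gives the first reading that is a number and not a limit, with chloro in place of hydrogen meta to a large group: an at least 1.4-fold lower number from compound 1 to compound 4 (0.14 log units; that floor lies within the scatter). The same number gives an at least 1.4-fold lower number from compound 3 to compound 4 (0.14 log units; that floor lies within the scatter) and an at least 1.4-fold lower number from compound 2 to compound 4 (0.14 log units; that floor lies within the scatter), so the place of the chloro now has a measured comparison, though none of these floors clears the scatter. The true size of all three steps stays unknown because only a floor can be read against the limit: the limit of > 10 ug/mL in this assay, at which 3 of the 4 values shown sit.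

Going by these compounds, it remains open whether a number of this kind belongs to chloro alone at this place or also appears with bromo, methoxy or trifluoromethyl there. On these data alone, it is also open how far compound 4 really lies from compound 1.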